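This account rests on a few compounds, and the source may have more. Where it says the series, first, only, none or still open, it means among the compounds named here.

Measured in a functional assay on MGC-803 cells (Homo sapiens) for inhibition, read by sulforhodamine B assay; a higher number here means a weaker inhibitor, a lower number a stronger inhibitor:

- compound 1 `O=C1C(Nc2cccc(Cl)c2)=CC(=O)c2c1nc1n2[C@H]2OC[C@@H](O)[C@H]2OC1` gives 1530 nM
- compound 2 `O=C1C=C(NCc2ccccc2)C(=O)c2c1nc1n2[C@H]2OC[C@@H](O)[C@H]2OC1` gives 2670 nM
- compound 3 `O=C1C=C(Nc2ccc(C(F)(F)F)cc2)C(=O)c2c1nc1n2[C@H]2OC[C@@H](O)[C@H]2OC1` gives 2820 nM

Compound 1 has the lowest of the three numbers in this assay, but its gaps to compound 2 and to compound 3 are both within the scatter, so nothing separates the three.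

Compound 4 `O=C1C(NCc2ccccc2)=CC(=O)c2c1nc1n2[C@H]2OC[C@@H](O)[C@H]2OC1` is not yet measured. It differs from compound 1 in one place: benzyl in place of 3-chlorophenyl on an amine nitrogen.

Within the data shown here, only one measured step is available, and it bears on this change only indirectly: from compound 2 to compound 3 an aryl group replaces benzyl on the amine nitrogen, with a 1.1-fold higher number from compound 2 to compound 3 (0.02 log units; within the scatter). Read in the other direction, an aryl-to-benzyl swap on this amine left the number essentially unchanged there, though on the other regioisomer of the shared core and with a different aryl substituent. Among the measured compounds shown here, no direct step from 3-chlorophenyl to benzyl is known.

The expectation for the step from compound 1 to compound 4 is therefore a 1.3-fold higher number from compound 1 to compound 4 (0.12 log units; within the scatter), within the scatter. Compound 4 is estimated at 2000 nM in this assay, with a range of 900 nM to 4500 nM.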

Compound 4, half-maximal inhibitory concentration: 3490 nM
Beside the measured number, compound 4's estimate is 1.7-fold (0.24 log units) below it; measured number inside the range.
By their numbers in this assay, from the lowest: compounds 1, 2, 3 and 4 (each within the scatter of the next, the first and the last beyond it).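

In this assay, among these compounds, the change from 3-chlorophenyl to benzyl on this amine nitrogen gives a 2.3-fold higher number from compound 1 to compound 4 (0.36 log units; beyond the scatter) and thus provides the first direct reading of this change on the core of compound 1. Among the compounds shown here, the only earlier step on this nitrogen showed a 1.1-fold higher number from compound 2 to compound 3 (0.02 log units; within the scatter) on the other regioisomer with a different aryl group, so that flat result does not carry over to this pair. Nothing available gives a reason for the step between these two compounds.

The change removes the chlorine and also places a carbon between the ring and the nitrogen, so the compounds shown do not separate these two differences. A plain phenyl or a 3-chlorobenzyl group on the same nitrogen would show which difference carries the step.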